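Methoxy to hydroxy on the weakest compound so far

This account rests on a few compounds, and the source may have more. Where it says the series, first, only, none or still open, it means among the compounds named here.

Compound 1 `COc1ccc(-c2ccccc2C(=O)/C=C/c2ccc(F)cc2)cc1OC`: 7100 nM
Compound 2 `COc1ccc(C(=O)/C=C/c2ccccc2-c2ccc(F)nc2)cc1`: 13000 nM
Compound 3 `COc1ccc(C(=O)/C=C/c2ccccc2-c2ccc(F)nc2)cc1OC`: 41000 nM

In a functional assay on MCF7 cells (Homo sapiens) for antiproliferative activity, read by sulforhodamine B assay, with a stated time of 48 h (a higher number here means a weaker inhibitor, a lower number a stronger inhibitor), compound 3 stands at 41000 nM, the highest of the three numbers and so the weakest of the three compounds, with both other compounds lower by more than the scatter. The next compound to be tested is compound 4 `COc1cc(C(=O)/C=C/c2ccccc2-c2ccc(F)nc2)ccc1O`. The change from compound 3 is hydrogen in place of methyl on an oxygen on an aromatic ring, or methoxy to hydroxy.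

Going by the values given here, no measured step makes this exact change. The closest evidence is a 3.2-fold higher number from compound 2 to compound 3 (0.50 log units; beyond the scatter), a modest step beyond the scatter, in which methoxy replaced hydrogen on an aromatic carbon. That change sits on a carbon rather than an oxygen, and it is a single pair, so it offers only a loose guide. It does suggest that the added methoxy of compound 3 came with a rise in the number, so a modest move back toward lower numbers is the likelier outcome in this assay. The expected change is a 2.1-fold lower number from compound 3 to compound 4 (0.31 log units; beyond the scatter), and a result within the scatter would remain possible. For compound 4 the estimate is 20000 nM, with an expected range from 7000 nM to 60000 nM.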

Compound 4, half-maximal inhibitory concentration: 27000 nM
Beside the measured number, compound 4's estimate is 1.4-fold (0.13 log units) below it; the range from low to high includes it.
By their numbers in this assay, from the lowest: compounds 1 and 2 (each within the scatter of the next); then compounds 4 and 3 (each within the scatter of the next).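

In this assay, going by these compounds alone, this pair is the first direct reading of the change on this oxygen, and it gives a 1.5-fold lower number from compound 3 to compound 4 (0.18 log units; within the scatter). Hydrogen in place of methyl on an oxygen on an aromatic ring therefore leaves the two compounds indistinguishable in this assay, a different picture from the earlier step on an aromatic carbon, which gave a 3.2-fold higher number from compound 2 to compound 3 (0.50 log units; beyond the scatter) when methoxy replaced hydrogen. So the one methoxy-to-hydroxy change on hand shows no shift beyond the scatter, although it rests on a single pair and nothing measured here bears on the reason for this outcome.

The compounds shown leave open whether a larger group on this oxygen, such as an ethoxy or a longer chain, or an amine in place of the hydroxy, would move the number beyond the scatter. They also leave open whether methoxy to hydroxy would read the same way on the core of compound 1, where the same kind of oxygen substituent sits on a differently arranged framework.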